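Methoxy-to-hydrogen step carried from one core to another

A few compounds are considered here, and "the series" means these few. Any claim that something is new, unique, unknown or untested is made for them only; others in the source may bear on it.

Measured so far in a functional assay on MCF7 cells (Homo sapiens) for inhibition, read by MTT assay, with a stated time of 48 h; on this read-out higher numbers stand for weaker inhibition and lower numbers for stronger inhibition:
compound 1, `c1ccc(-c2ccnc3c2c(-c2ccccc2)nn3-c2ccccc2)cc1`, gives 28200 nM.
compound 2, `COc1ccc(-c2ccnc3c2c(-c2ccccc2)nn3-c2ccccc2)cc1`, gives 28700 nM.
compound 3, `COc1ccc(-c2nc3c(c(-c4ccccc4)nn3-c3ccccc3)c(-c3ccc(N4CCN(C)CC4)cc3)c2C#N)cc1`, gives 2650 nM.

Compound 2 and compound 1 differ in a single place, (hydrogen in place of methoxy on an aromatic carbon). The step measured was a 1.0-fold lower number from compound 2 to compound 1 (0.01 log units; within the scatter), so the two values show nothing that can be read as a change. Compound 3 gives the lowest number of the three, and its gaps to compound 1 and to compound 2 both lie beyond the scatter. The difference between the core of compound 3 and the core of compound 2 is not broken down here.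

Compound 4, `CN1CCN(c2ccc(-c3c(C#N)c(-c4ccccc4)nc4c3c(-c3ccccc3)nn4-c3ccccc3)cc2)CC1`, is not yet measured. It differs from compound 3 by hydrogen in place of methoxy on an aromatic carbon. The place of this change is described in the same words as the place of the change from compound 2 to compound 1, so it is the same change, now made on the core of compound 3. The step from compound 3 to compound 4 is expected to be about a 1.0-fold higher number from compound 3 to compound 4 (0.01 log units; within the scatter) because the same change gave a 1.0-fold lower number from compound 2 to compound 1 (0.01 log units; within the scatter) on the other core. Compound 4 is therefore expected to give roughly 2700 nM in this assay. Among the measured compounds shown here, the estimate for compound 4 is taken to lie between 1200 nM and 6000 nM, the range widened because only one earlier step, a 1.0-fold lower number from compound 2 to compound 1 (0.01 log units; within the scatter), supports it and the cores differ.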

Compound 4, half-maximal inhibitory concentration: 14300 nM
Compound 4: middle estimate off by 5.3-fold (0.72 log units), on the low side, outside the stated range (above it).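

In this assay, the change from 4-methoxyphenyl to phenyl on the core of compound 3 gives a 5.4-fold higher number from compound 3 to compound 4 (0.73 log units; beyond the scatter), whereas on the core of compound 1 the same change shows no readable effect, with a 1.0-fold lower number from compound 2 to compound 1 (0.01 log units; within the scatter). The methoxy-to-hydrogen step therefore does not carry over unchanged from one core to the other, and the flat result on the first core gives no safe guide to the second: the same change on two cores in this assay, a 1.0-fold lower number (0.01 log units; within the scatter) from compound 2 to compound 1 and a 5.4-fold higher number (0.73 log units; beyond the scatter) from compound 3 to compound 4, 5.5-fold (0.74 log units) apart, beyond the scatter of two such steps. This comparison rests on a single pair on each core, so it does not show which feature of the core of compound 3 sets the two steps apart, nor how the step would behave on any further core.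

The compounds shown leave open whether the step on the core of compound 3 is specific to methoxy, since no other group occupies that place on the ring; a hydroxyl, a fluorine, an amine or a longer chain such as ethoxy would help settle this. Also open, from the compounds shown here alone, is whether the nitrile or the methylpiperazine group on that core is what the size of the step depends on, which would need a pair with one of these groups changed and the methoxy step repeated.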